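This account rests on a few compounds, and the source may have more. Where it says the series, first, only, none or still open, it means among the compounds named here.

Measured in a functional assay on MOLT-4 cells (Homo sapiens) for antiproliferative activity; on this read-out higher numbers stand for weaker inhibition and lower numbers for stronger inhibition:
- compound 1 `COc1cc(C(=O)c2sc(-c3ccc([N+](=O)[O-])cc3)cc2N)cc(OC)c1OC`: 110 nM
- compound 2 `COc1cc(C(=O)c2sc(-c3ccc(Cl)cc3)cc2N)cc(OC)c1OC`: 77 nM
- compound 3 `COc1cc(C(=O)c2sc(-c3ccc(I)cc3)cc2N)cc(OC)c1OC`: 190 nM

These three compounds differ in one place, carrying nitro, chloro or iodo on an aromatic carbon. Exchanging nitro for chloro gives a 1.4-fold lower number from compound 1 to compound 2 (0.15 log units; within the scatter). Exchanging nitro for iodo gives a 1.7-fold higher number from compound 1 to compound 3 (0.24 log units; within the scatter). Compound 3 therefore cannot be separated from compound 1, and it stands apart only from compound 2, with a 2.5-fold higher number from compound 2 to compound 3 (0.39 log units; beyond the scatter).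

Compound 4 `COc1cccc(-c2cc(N)c(C(=O)c3cc(OC)c(OC)c(OC)c3)s2)c1` has not yet been measured. It carries 3-methoxyphenyl in place of 4-iodophenyl, on an aromatic carbon of a five-membered aromatic ring with 1 sulfur, next to the ring sulfur (3-methoxyphenyl in place of 4-iodophenyl on an aromatic carbon). Going by the values given here, no measured compound carries 3-methoxyphenyl, so the three exchanges bear on this change only indirectly. Even the largest of them is modest, so no large move is expected in this assay. A slight lean towards a lower number rests on compound 2, with a 2.5-fold higher number from compound 2 to compound 3 (0.39 log units; beyond the scatter), but a step beyond the scatter is not expected. The estimated step is a 1.6-fold lower number from compound 3 to compound 4 (0.20 log units; within the scatter). For compound 4 the estimated value is 120 nM, with an expected range of 35 nM to 400 nM.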

Compound 4, half-maximal inhibitory concentration: 17 nM
Compound 4: the middle estimate sits 7.1-fold (0.85 log units) above what was measured; the whole stated range lies above it.
By their numbers in this assay, from the lowest: compound 4; then compounds 2, 1 and 3 (each within the scatter of the next, the first and the last beyond it).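

In this assay, the aryl group on the aromatic carbon next to the ring sulfur moves the read-out much further than the exchanges among nitro, chloro and iodo had shown: 3-methoxyphenyl in place of 4-iodophenyl gives (an 11-fold lower number from compound 3 to compound 4 (1.05 log units; beyond the scatter)), the only large step in the set. The change is not tied to the loss of iodo alone, as 3-methoxyphenyl in place of 4-chlorophenyl gives (a 4.5-fold lower number from compound 2 to compound 4 (0.66 log units; beyond the scatter)) and in place of 4-nitrophenyl gives (a 6.5-fold lower number from compound 1 to compound 4 (0.81 log units; beyond the scatter)), which makes compound 4 the most potent of the four, with each of its steps beyond the scatter. Nothing measured here gives a reason for the size of these steps.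

The compounds shown leave open whether the methoxy group itself or its place on the phenyl ring carries this change, as compound 4 differs from compounds 1, 2 and 3 in both respects at once. Going by these compounds, it also remains open whether a hydroxyl, an ethoxy group or an unsubstituted phenyl ring would hold the number that compound 4 reaches.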